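Amide substituent variation in a cathepsin S inhibitor series

The compounds below may be only part of what the source reports. "The series", "measured", "known", "first", "only" and "open" are said of these compounds alone.

Measured so far:
compound 1 `N#CC1(NC(=O)[C@@H]2C[C@@H](S(=O)(=O)c3ccccc3)C[C@H]2C(=O)N2CC3(COC3)C2)CC1` gives 3 nM in an assay on isolated protein for inhibition of cathepsin S (Homo sapiens), read by fluorescence, with a stated time of 20 min; a lower number here means a stronger inhibitor, a higher number a weaker inhibitor
compound 2 `CC1CCN(C(=O)[C@@H]2C[C@H](S(=O)(=O)c3ccccc3)C[C@H]2C(=O)NC2(C#N)CC2)CC1` gives 0.5 nM in this assay
compound 3 `N#CC1(NC(=O)[C@@H]2C[C@@H](S(=O)(=O)c3ccccc3)C[C@H]2C(=O)N2CCC(O)CC2)CC1` gives 1 nM in this assay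

Compound 3 stands second highest of the three numbers. Its nearest neighbour is compound 2, with a 2.0-fold higher number from compound 2 to compound 3 (0.30 log units; within the scatter) lying within the scatter; the furthest is compound 1, with a 3.0-fold lower number from compound 1 to compound 3 (0.48 log units; beyond the scatter) lying beyond it.

Compound 4 `N#CC1(NC(=O)[C@@H]2C[C@@H](S(=O)(=O)c3ccccc3)C[C@H]2C(=O)N2CCS(=O)(=O)CC2)CC1` differs from compound 3 by 1,1-dioxothiomorpholin-4-yl in place of 4-hydroxypiperidin-1-yl on a carbonyl carbon. Going by the values given here, the steps that bear on this position are those on the carbonyl carbon: a 6.0-fold lower number from compound 1 to compound 2 (0.78 log units; beyond the scatter) and a 3.0-fold lower number from compound 1 to compound 3 (0.48 log units; beyond the scatter), both modest, both exchanging the group with two four-membered rings for a six-membered ring. Among the compounds with values here, the only step between two six-membered rings, a 2.0-fold higher number from compound 2 to compound 3 (0.30 log units; within the scatter), is within the scatter. Within the data shown here, no measured step introduces the 1,1-dioxothiomorpholin-4-yl group, so the direction is uncertain; a step of about the size seen between six-membered rings, or somewhat larger towards a higher number, is expected, giving a 2.0-fold higher number from compound 3 to compound 4 (0.30 log units; within the scatter). Compound 4 is therefore estimated at 2 nM, with a range from 0.7 nM to 6 nM.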

Compound 4, half-maximal inhibitory concentration: 4 nM
Estimate against measurement, compound 4: 2.0-fold (0.30 log units) below, and the stated range covers the measured number.
By their numbers in this assay, from the lowest: compounds 2 and 3 (each within the scatter of the next); then compounds 1 and 4 (each within the scatter of the next).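

In this assay, a six-membered ring on the carbonyl carbon no longer guarantees the lowest numbers: 1,1-dioxothiomorpholin-4-yl in place of 4-hydroxypiperidin-1-yl gives a 4.0-fold higher number from compound 3 to compound 4 (0.60 log units; beyond the scatter), and in place of 4-methylpiperidin-1-yl it gives an 8.0-fold higher number from compound 2 to compound 4 (0.90 log units; beyond the scatter). Against the group with two four-membered rings, the new group gives a 1.3-fold higher number from compound 1 to compound 4 (0.12 log units; within the scatter), so the advantage that compounds 2 and 3 hold over compound 1 does not extend to compound 4. Nothing shown here accounts for these steps.

On these data alone, it remains open whether a morpholine or piperazine ring on the same carbonyl carbon would group with compounds 2 and 3 or with compounds 1 and 4. Also open, as far as these compounds go, is whether an amine at the 4-position of the piperidine would stay with compounds 2 and 3.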